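The source may hold more compounds than are shown below. What is called first, only, known or untested is meant among the compounds shown, and "the series" means these compounds.

Three measured compounds anchor this small series. Compound 1 `C[Se]/C(=N\C(=O)c1cccs1)NC(=O)c1cccs1` was tested in a functional assay on MCF7 cells (Homo sapiens) for cytotoxicity, read by MTT assay, with a stated time of 72 h; a higher number here means that more compound is tolerated, a lower number that less compound is tolerated; in this assay compound 1 reaches only the limit of > 100000 nM. Compound 2 `O=C(/N=C(/NC(=O)c1cccs1)[Se]Cc1ccccc1)c1cccs1` likewise returns a limit in this assay, where compound 2 gives > 100000 nM. The step that the two limits leave unreadable from compound 1 to compound 2 therefore cannot be sized, because both of its ends are limits. Compound 3 `C[Se]/C(=N\C(=O)c1ccno1)NC(=O)c1ccno1` also stops at a limit in this assay, with compound 3 at > 100000 nM. All three thus share (the limit of > 100000 nM in this assay, at which 3 of the 3 values shown sit), and compound 2 stands at that limit, with the two further values shown being limits as well.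

Compound 4 `CS/C(=N\C(=O)c1cccs1)NC(=O)c1cccs1` has not yet been measured. It differs from compound 2 by a group of 2 heavy atoms (1 carbon, 1 sulfur; no ring) in place of a group of 8 heavy atoms (7 carbon, 1 selenium; one six-membered aromatic ring of carbon only), on a carbon with a double bond to nitrogen. Among the compounds with values here, only one measured step touches this site, and that step is unreadable, so no step of known size guides the expectation. Within the data shown here, since every value so far is a limit, compound 4 is expected to show no step beyond the scatter, a step that the limit leaves unreadable from compound 2 to compound 4. Compound 4 is accordingly estimated at 150000 nM, within a range from 50000 nM to 500000 nM, and is expected most likely to return again only a limit.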

Compound 4, concentration lethal to 50% of the cells: > 100000 nM
Compound 4 gave a limit, no number (the forecaster's own chance of this, stated with the estimate: 85%); the middle value does not contradict the limit.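

The steps to compound 4 from compound 1 and from compound 2 cannot be read, because all of these values are limits, not numbers: the limit of > 100000 nM in this assay, at which 4 of the 4 values shown sit.

The compounds shown leave open whether changing the group on the carbon with a double bond to nitrogen alters cytotoxicity at all.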